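The source may hold more compounds than are shown below. What is called first, only, known or untested is meant among the compounds shown, and "the series" means these compounds.

In a functional assay on SK-MEL-2 cells (Homo sapiens) for antiproliferative activity (on this read-out higher numbers stand for weaker inhibition of growth and lower numbers for stronger inhibition of growth), compound 3 (`c1ccc(-c2cc(-c3cccs3)cc(-c3ccccn3)n2)nc1`) gives 1.8 ug/mL, the second highest of three numbers. Compound 1 (`c1ccc(-c2cc(-c3ccsc3)cc(-c3ccccn3)n2)nc1`) gives 0.89 ug/mL and compound 2 (`c1ccc(-c2cc(-c3ccccn3)nc(-c3ccccn3)c2)cc1`) gives 7.5 ug/mL. Compound 4 (`c1ccc(-c2cc(-c3cccs3)cc(-c3ccncc3)n2)nc1`) carries pyridin-4-yl in place of pyridin-2-yl on an aromatic carbon. Among the measured compounds shown here, no measured step covers this exchange. For the measured compounds named here, the only guides are the swaps among thiophen-3-yl, thiophen-2-yl and phenyl, elsewhere on the shared core: a 2.0-fold higher number from compound 1 to compound 3 (0.31 log units; beyond the scatter), a 4.2-fold lower number from compound 2 to compound 3 (0.62 log units; beyond the scatter) and an 8.4-fold higher number from compound 1 to compound 2 (0.93 log units; beyond the scatter). All three are modest but beyond the scatter. A similarly modest step in this assay is therefore expected, probably toward a higher number, although the direction remains uncertain. The expected step is a 1.7-fold higher number from compound 3 to compound 4 (0.22 log units; within the scatter). For compound 4 the estimated value is 3 ug/mL, with an expected range of 0.9 ug/mL to 9 ug/mL.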

Compound 4, concentration for 50% growth inhibition: 35.2 ug/mL
Beside the measured number, compound 4's estimate is 12-fold (1.07 log units) below it, outside the stated range (above it).
By their numbers in this assay, from the lowest: compound 1; then compound 3; then compound 2; then compound 4.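

Among the compounds shown here, at this place on the shared core, the position of the nitrogen within the pyridine ring matters strongly in this assay: pyridin-4-yl in place of pyridin-2-yl gives a 20-fold higher number from compound 3 to compound 4 (1.29 log units; beyond the scatter) and is the only step graded large. The two compounds have the same atoms, joined differently, so the step comes from the attachment of the ring alone. Nothing at hand explains this loss of growth inhibition.

Still open, as far as these compounds go, is how pyridin-3-yl or phenyl would read at this place. Also open, from the compounds shown here alone, is whether the same exchange at the remaining pyridin-2-yl group gives a comparable step.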